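Thiophen-2-yl replaces furan-3-yl on the shared core

This account rests on a few compounds, and the source may have more. Where it says the series, first, only, none or still open, it means among the compounds named here.

In an ADME assay on MRC5 cells (Homo sapiens), read by MTT assay, with a stated time of 72 h (a higher number here means a weaker inhibitor, a lower number a stronger inhibitor), compound 1 `CNc1ncnc2c1c(-c1ccco1)cn2[C@@H]1O[C@H](CO)[C@@H](O)[C@H]1O` gives 90800 nM. Compound 2 `CNc1ncnc2c1c(-c1ccoc1)cn2[C@@H]1O[C@H](CO)[C@@H](O)[C@H]1O` gives > 100000 nM, which is a limit of the assay and not a number. Compound 3 `CNc1ncnc2c1c(-c1cccs1)cn2[C@@H]1O[C@H](CO)[C@@H](O)[C@H]1O` carries thiophen-2-yl in place of furan-3-yl on an aromatic carbon. Within the data shown here, the one measured step at this carbon, furan-3-yl in place of furan-2-yl, is an at least 1.1-fold higher number from compound 1 to compound 2 (0.04 log units; that floor lies within the scatter), so it offers only a floor that lies within the scatter. No change beyond the scatter is therefore expected in this assay, and the estimated step is an at least 1.2-fold lower number from compound 2 to compound 3 (0.09 log units; that floor lies within the scatter). For compound 3 the expected value is 80000 nM, with an estimated range of 30000 nM to 100000 nM.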

Compound 3, half-maximal inhibitory concentration: > 100000 nM
Compound 3: a limit, no number (the forecaster's own chance of this, stated with the estimate: 50%); middle value at least 1.2-fold (0.09 log units) away from the limit.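

In this assay the sulfur ring at this aromatic carbon behaves no differently from the oxygen rings as far as can be told, and compound 3 gives > 100000 nM, which is a limit of the assay and not a number. Thiophen-2-yl in place of furan-2-yl gives an at least 1.1-fold higher number from compound 1 to compound 3 (0.04 log units; that floor lies within the scatter), so only a floor within the scatter is known. The step between the two compounds at the limit cannot be read because both values stop there: the limit of > 100000 nM in this assay, at which 2 of the 3 values shown sit.

All three groups shown are five-membered aromatic rings with 1 hetero atom. From the compounds shown here alone, an amine or a carboxylic acid on this carbon remains open, as does the true value of compound 2 and compound 3.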